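Ethyl in Place of Hydroxy: Looking Ahead to Compound 4

A few compounds are considered here, and "the series" means these few. Any claim that something is new, unique, unknown or untested is made for them only; others in the source may bear on it.

Compound 1, `CN(C)/N=N/c1ccc(S(=O)(=O)Nc2ncccn2)cc1`: 3.74
Compound 2, `CN(CCO)/N=N/c1[nH]cnc1C(N)=O`: 3.12
Compound 3, `CN(C)/N=N/c1cc(Cl)cc(C(N)=O)c1Cl`: 3.04

Of the compounds shown here, three have been tested in a functional assay on L1210 cells (Mus musculus) for antiproliferative activity; on this read-out lower numbers stand for lower potency and higher numbers for higher potency (the scale is a negative logarithm). Compound 1 gives 3.74, compound 2 gives 3.12 and compound 3 gives 3.04. Compound 2 has the second highest of the three numbers. Its nearest neighbour is compound 3, whose value lies within the usual scatter of compound 2, so the two cannot be told apart. Compound 1 stands clearly higher than compound 2, beyond the scatter.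

The next compound, compound 4, `CCCCN(C)/N=N/c1[nH]cnc1C(N)=O`, is built from compound 2 by a single change: ethyl in place of hydroxy on a saturated chain carbon, two bonds along the chain from an amine nitrogen. Among the measured compounds shown here, no pair among the three measured compounds differs in just one place, so no measured step shows what such a change has done before, and the expectation rests on the change alone. An exchange of this kind, ethyl in place of hydroxy on a saturated chain carbon, is expected to move the number in this assay only a little, in either direction, and most likely not beyond the scatter.

Compound 4 is therefore estimated at 3.2 in this assay, with a range from 2.7 to 3.7. The expected step of a number 0.08 log units higher from compound 2 to compound 4 (within the scatter) is small.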

Compound 4, logarithm of the reciprocal of the active concentration, log(1/C): 3.54
The estimate for compound 4 lay 0.34 log units below the measured number; the measured number falls inside the stated range.
By their numbers in this assay, from the lowest: compounds 3 and 2 (each within the scatter of the next); then compounds 4 and 1 (each within the scatter of the next).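

In this assay, ethyl in place of hydroxy on a saturated chain carbon, two bonds along the chain from an amine nitrogen, gives a number 0.42 log units higher from compound 2 to compound 4 (beyond the scatter). Among the compounds shown here, this is the first single change in the set that can be read directly, as the earlier compounds differ from one another in more than one place. It shows that this part of the chain is not indifferent to the exchange, and that the shared core can carry butyl instead of 2-hydroxyethyl with no loss in this assay. No measurement available here explains why the number rises.

A single step cannot separate the effect of losing the hydroxy from that of adding carbon, so the two remain tangled together in this comparison. As far as these compounds go, it also remains open how the number in this assay would respond to an amine, a carboxylic acid or a methoxy group in place of the ethyl, or to a longer chain such as hexyl, and whether the rise would continue, level off or reverse.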